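Furanylmethylamino in place of phenylsulfonylaminomethyl on the shared core

This account rests on a few compounds, and the source may have more. Where it says the series, first, only, none or still open, it means among the compounds named here.

Compound 1 `O=S(=O)(NCC1CCN(CCCc2c[nH]c3ccc(-n4cnnc4)cc23)CC1)c1ccccc1` gives 12 nM in an assay on CHO cells for agonist activity at 5-hydroxytryptamine receptor 1D (Homo sapiens), read by GTPgammaS binding; a higher number here means that more compound is needed for the effect, a lower number that less compound is needed. Of the three measured numbers, compound 1 has the highest; its nearest neighbour is compound 2 `c1ccc(CNCC2CCN(CCCc3c[nH]c4ccc(-n5cnnc5)cc34)CC2)cc1` at 5.6 nM, a step of a 2.1-fold lower number from compound 1 to compound 2 (0.33 log units; beyond the scatter), and the furthest is compound 3 `CN(Cc1ccsc1)C1CCN(CCCc2c[nH]c3ccc(-n4cnnc4)cc23)CC1` at 4.2 nM, a step of a 2.9-fold lower number from compound 1 to compound 3 (0.46 log units; beyond the scatter). Between compound 2 and compound 3 the step is a 1.3-fold lower number from compound 2 to compound 3 (0.12 log units; within the scatter).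

Compound 4 `c1cc(CNC2CCN(CCCc3c[nH]c4ccc(-n5cnnc5)cc34)CC2)co1` is not yet measured. Relative to compound 1 the change is ((furan-3-yl)methyl)amino in place of ((phenylsulfonyl)amino)methyl on a saturated ring carbon. Among the compounds with values here, two measured steps bear on it: both replacements of the phenylsulfonyl amide by a basic amine bearing an arylmethyl group, a 2.1-fold lower number from compound 1 to compound 2 (0.33 log units; beyond the scatter) and a 2.9-fold lower number from compound 1 to compound 3 (0.46 log units; beyond the scatter), gave modest drops in this assay. Compound 4 carries the same kind of group, an amine with a five-membered aromatic ring, directly on the ring carbon as in compound 3, so a modest step in the same direction, a 2.4-fold lower number from compound 1 to compound 4 (0.38 log units; beyond the scatter), is expected. Compound 4 is therefore estimated at 5 nM, with a range from 2 nM to 14 nM.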

Compound 4, half-maximal effective concentration: 7.1 nM
Estimate against measurement, compound 4: 1.4-fold (0.15 log units) below; the range from low to high includes it.
By their numbers in this assay, from the lowest: compounds 3, 2, 4 and 1 (each within the scatter of the next, the first and the last beyond it).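

In this assay, ((furan-3-yl)methyl)amino in place of ((phenylsulfonyl)amino)methyl on a saturated ring carbon gives a 1.7-fold lower number from compound 1 to compound 4 (0.23 log units; within the scatter), whereas the two earlier replacements of the phenylsulfonyl-bearing group were printed beyond the scatter, so an amine bearing an aromatic ring does not always separate from compound 1. The furan-bearing amine also cannot be told apart from the other two amines at this position: a 1.7-fold higher number from compound 3 to compound 4 (0.23 log units; within the scatter) and a 1.3-fold higher number from compound 2 to compound 4 (0.10 log units; within the scatter). Nothing available here accounts for these steps.

Open, on these data alone, is whether a methyl group on the amine nitrogen of compound 4 would shift the number, which would give a direct comparison with the tertiary amine of compound 3. Also open, as far as these compounds go, is what a pyridine ring or a longer chain in place of the (furan-3-yl)methyl group would give.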